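This account rests on a few compounds, and the source may have more. Where it says the series, first, only, none or still open, it means among the compounds named here.

Measured compounds:
compound 1, `Fc1cccc(Cn2ccc3nc(-c4ccccc4)nc-3c2)c1`: > 100000 nM
compound 2, `CC(C)(C)c1ccc(Cn2ccc3nc(-c4ccccc4)nc-3c2)cc1`: 22000 nM

In an ADME assay on MDBK cells (Bos taurus) for cytotoxicity (a higher number here means that more compound is tolerated, a lower number that less compound is tolerated), compound 1 gives > 100000 nM; this is a limit of the assay, not a number. Compound 1 therefore stands at the limit of > 100000 nM in this assay, at which 1 of the 2 values shown sits. Compound 2 gives 22000 nM, a measured number in this assay. Among the measured compounds shown here, no step between these two compounds is counted here; their two values show only that compound 2 has a number where compound 1 has a limit.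

Compound 3, `CC(C)=CCn1ccc2nc(-c3ccccc3)nc-2c1`, is not yet measured in this assay. It differs from compound 1 as follows: 2-methylprop-1-en-1-yl in place of 3-fluorophenyl on a saturated chain carbon bound to an aromatic nitrogen. The shared core is kept. For the measured compounds named here, with compound 1 at a limit, no measured step is available to set the size of this change. The expectation is that the step of a number no higher from compound 1 to compound 3 (the limit leaves the size open) stays within the scatter, so that compound 3 is expected to remain near the limit. Compound 3 is estimated at 100000 nM, with a range from 35000 nM to 300000 nM.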

Compound 3, half-maximal cytotoxic concentration: > 100000 nM
Compound 3: only a limit was reported; the forecaster's own chance of this, stated with the estimate: 55%; the middle value sits exactly at the limit.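

In this assay no step can be read between compound 1 and compound 3 because both compounds stand at a limit of the assay: the limit of > 100000 nM in this assay, at which 2 of the 3 values shown sit.

The compounds shown leave open how far 2-methylprop-1-en-1-yl and 3-fluorophenyl differ in this assay on a saturated chain carbon bound to an aromatic nitrogen.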